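This account rests on a few compounds, and the source may have more. Where it says the series, first, only, none or still open, it means among the compounds named here.

Measured in a functional assay on the whole organism with Rattus norvegicus as the target; a higher number here means that more compound is needed for the effect, a lower number that less compound is needed:
- compound 1 `N=c1sc2cc(OC(F)(F)F)ccc2n1CC(=O)O`: > 10 mg/kg (a limit)
- compound 2 `C[S+]([O-])CCn1c(=N)sc2cc(OC(F)(F)F)ccc21`: 1.1 mg/kg
- compound 3 `CNCCn1c(=N)sc2cc(OC(F)(F)F)ccc21`: > 10 mg/kg (a limit)

Compound 3 gives > 10 mg/kg, which is a limit and not a number. The change to compound 4 `CN(CCn1c(=N)sc2cc(OC(F)(F)F)ccc21)Cc1ccccc1` is benzyl in place of hydrogen on an amine nitrogen. Within the data shown here, no measured step touches this amine nitrogen. The nearest evidence is an at least 9.0-fold higher number from compound 2 to compound 3 (0.95 log units; beyond the scatter), and an at least 9.0-fold lower number from compound 1 to compound 2 (0.95 log units; beyond the scatter) likewise shows that changes on this chain can move the number beyond the scatter. The remaining step, a step that the two limits leave unreadable from compound 1 to compound 3, cannot be read. A modest move toward a lower number in this assay is therefore expected, though the result may stay a limit. The estimated step is an at least 1.4-fold lower number from compound 3 to compound 4 (0.15 log units; that floor lies within the scatter). For compound 4 the expected value is 7 mg/kg, with an estimated range of 1.5 mg/kg to 25 mg/kg.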

Compound 4, dose for half-maximal effect: 7 mg/kg
Beside the measured number, compound 4's estimate shows no gap at the digits printed; measured number inside the range.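

In this assay, benzyl in place of hydrogen on an amine nitrogen gives an at least 1.4-fold lower number from compound 3 to compound 4 (0.15 log units; that floor lies within the scatter), the only step shown at this nitrogen. With benzyl on this nitrogen, the result becomes a readable number rather than a limit. On these data alone, compound 3 gives > 10 mg/kg, which is a limit and not a number, so the true size of the step stays unknown: the limit of > 10 mg/kg in this assay, at which 2 of the 4 values shown sit.

As far as these compounds go, whether the aromatic ring itself matters remains open. A cyclohexylmethyl group or a plain ethyl on this amine nitrogen would test that, and a substituted benzyl would test how far the ring can be changed.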